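Swapping the Acetylpiperazine Tail for an Acetylpiperidine

The source may hold more compounds than are shown below. What is called first, only, known or untested is meant among the compounds shown, and "the series" means these compounds.

Of the compounds shown here, three sharing one core have been measured in an assay on isolated protein for binding affinity to 5-hydroxytryptamine receptor 4 (Homo sapiens); on this read-out higher numbers stand for weaker inhibition and lower numbers for stronger inhibition. Compound 1 `CS(=O)(=O)N1CCN(CC(O)CN2CCC(CNC(=O)c3cccc4[nH]cnc34)CC2)CC1` gives 6.31 nM. Within the data shown here, compound 2 `CCc1nc2c(C(=O)NCC3CCN(CC(O)CN4CCN(S(C)(=O)=O)CC4)CC3)cccc2[nH]1` gives 0.501 nM, and the single one-point step measured so far, a 13-fold lower number from compound 1 to compound 2 (1.10 log units; beyond the scatter), lies on the aromatic part of the core. Compound 3 `CC(=O)N1CCN(CCN2CCC(CNC(=O)c3cccc4[nH]c(C(C)C)nc34)CC2)CC1` gives 5.01 nM; it stands second highest of the three numbers, nearest to compound 1 and within the scatter of it, while its gap to compound 2 is beyond the scatter.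

Compound 4 `CC(=O)N1CCC(CN2CCC(CNC(=O)c3cccc4[nH]c(C(C)C)nc34)CC2)CC1` has not yet been measured. It differs from compound 3 in one place: 1-acetylpiperidin-4-yl in place of (4-acetylpiperazin-1-yl)methyl on a saturated chain carbon bound to an amine nitrogen in a ring. Seen one bond further out, the same change reads 2-(4-acetylpiperazin-1-yl)ethyl to (1-acetylpiperidin-4-yl)methyl.

Among the measured compounds shown here, no measured step touches this part of the molecule. For the measured compounds named here, the only step known concerns an aromatic carbon, and the tails of compound 1 and compound 3 differ without any step recorded between them, so nothing in the data speaks for a large move in this assay. The step expected here is a 1.0-fold lower number from compound 3 to compound 4 (0.00 log units; within the scatter), a change that would stay within the scatter. The estimate for compound 4 in this assay is 5 nM, within a range from 1.5 nM to 20 nM.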

Compound 4, inhibition constant: 1 nM
For compound 4 the middle estimate is 5.0-fold (0.70 log units) above the measured one, and the stated range ends above it.
By their numbers in this assay, from the lowest: compounds 2 and 4 (each within the scatter of the next); then compounds 3 and 1 (each within the scatter of the next).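

Among these compounds, this is the first measured step on the tail of the molecule, and in this assay replacing (4-acetylpiperazin-1-yl)methyl with 1-acetylpiperidin-4-yl gives a 5.0-fold lower number from compound 3 to compound 4 (0.70 log units; beyond the scatter). The step is modest but lies beyond the scatter, so the read-out does respond to a change at this place, on a saturated chain carbon bound to an amine nitrogen in a ring, even when the two groups look much alike. The entering group has one heavy atom fewer, one ring hetero atom rather than two and one hydrogen-bond acceptor rather than two, but this single pair cannot separate those differences, and no measurement at hand explains the step.

As far as these compounds go, it remains open whether the same swap would give a step of similar size on a molecule with the tail of compound 1, which carries a methylsulfonyl group and a hydroxyl-bearing chain. From the compounds shown here alone, it is also open how this read-out would respond to a morpholine ring or a plain cyclohexyl ring in place of 1-acetylpiperidin-4-yl, or to a free amine in place of the acetyl group.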